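Swapping the Hydrazone Aryl Group: Nitro to Chloro

A few compounds are considered here, and "the series" means these few. Any claim that something is new, unique, unknown or untested is made for them only; others in the source may bear on it.

Measured so far in a functional assay on NCI60 cells (Homo sapiens) for cytotoxicity, read by sulforhodamine B assay, with a stated time of 48 h; on this read-out higher numbers stand for weaker inhibition of growth and lower numbers for stronger inhibition of growth:
compound 1, `Cc1cc(Cl)ccc1Nc1nc(C(F)(F)F)ccc1C(=O)N/N=C/c1ccc([N+](=O)[O-])cc1`, gives 4680 nM
compound 2, `Cc1cc(Cl)ccc1Nc1nc(C(F)(F)F)ccc1C(=O)N/N=C/c1ccccc1Cl`, gives 5130 nM

Among these two numbers compound 1 stands lowest, with compound 2 nearest to it; the step of a 1.1-fold higher number from compound 1 to compound 2 (0.04 log units; within the scatter) lies within the scatter, so the two compounds cannot be told apart on this read-out. Compound 3, `Cc1cc(Cl)ccc1Nc1nc(C(F)(F)F)ccc1C(=O)N/N=C/c1ccc(Cl)cc1`, has not yet been measured in this assay. It differs from compound 1 by chloro in place of nitro on an aromatic carbon, in words chloro in place of nitro on an aromatic carbon. Among the compounds with values here, only one measured step bears on this change: a 1.1-fold higher number from compound 1 to compound 2 (0.04 log units; within the scatter) also removes the 4-nitrophenyl in favour of a chlorophenyl and produced nothing beyond the scatter. Within the data shown here, with that single step as the only guide, a move of the chloro to the position named under the difference is not expected to open a gap either. Compound 3 is therefore expected to show a step of a 1.0-fold higher number from compound 1 to compound 3 (0.01 log units; within the scatter), meaning no step beyond the scatter. Compound 3 is estimated at 4800 nM in this assay, with a range from 2400 nM to 9600 nM.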

Compound 3, concentration for total growth inhibition: 7590 nM
Compound 3: middle estimate off by 1.6-fold (0.20 log units), on the low side; the range from low to high includes it.
By their numbers in this assay, from the lowest: compounds 1, 2 and 3 (each within the scatter of the next).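

In this assay, the direct exchange on the aromatic carbon para to a large group gives a 1.6-fold higher number from compound 1 to compound 3 (0.21 log units; within the scatter) and thus replaces the earlier indirect comparison with a reading of 4-nitrophenyl to 4-chlorophenyl at this very position, which stays within the scatter. The two chlorophenyl compounds add a second point: 4-chlorophenyl in place of 2-chlorophenyl gives a 1.5-fold higher number from compound 2 to compound 3 (0.17 log units; within the scatter) and shows that these two placements of the chloro cannot be told apart on this read-out, so all three aryl variants remain indistinguishable in each listed comparison. Nothing available offers an explanation for these readings, and no further data bear on them.

The compounds shown leave open whether an amine, a carboxylic acid or a methoxy group on the same aromatic carbon would produce a step beyond the scatter, or whether such a step needs a longer chain in place of the aryl group altogether. They also leave open how far these readings depend on the shared core, which is the same in all three compounds, including its trifluoromethyl group and its amide hydrogen.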